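The source may hold more compounds than are shown below. What is called first, only, known or untested is meant among the compounds shown, and "the series" means these compounds.

Compound 1 `FC(F)(F)c1ccc(Nc2ncnc3sc(Nc4c(Cl)cccc4Cl)nc23)cc1` is the reference point of this small set. Going by the values given here, in a functional assay on HEK293 cells for antagonist activity at transient receptor potential cation channel subfamily V member 1 (Homo sapiens), read by calcium flux (on this read-out higher numbers stand for weaker inhibition and lower numbers for stronger inhibition), compound 1 gives 12 nM, the lowest of the three numbers measured so far. Compound 2 `Cc1ccc(Nc2ncnc3sc(Nc4c(Cl)cccc4Cl)nc23)cc1` carries a methyl where compound 1 carries a trifluoromethyl; in this assay compound 2 gives 33 nM, and the change amounts to a 2.8-fold higher number from compound 1 to compound 2 (0.44 log units; beyond the scatter). Compound 3 `FC(F)(F)c1ccc(Nc2ncnc3sc(Nc4c(Cl)cccc4Cl)nc23)cc1Cl`, with an added chloro on the same aryl ring, gives 21 nM, a step of a 1.8-fold higher number from compound 1 to compound 3 (0.24 log units; within the scatter).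

Compound 4 `FC(F)(F)c1ccc(Nc2nc(N3CCC3)nc3sc(Nc4c(Cl)cccc4Cl)nc23)cc1` differs from compound 1 by azetidin-1-yl in place of hydrogen on an aromatic carbon; the new group sits on an aromatic carbon of the shared core, between two ring nitrogen atoms. Both measured steps concern the aryl ring on the anilino side, not the core, so none of them bears directly on this change. With no core substitution measured in this assay, the direction is open; the expectation is a number close to that of compound 1, with a step of a 1.7-fold higher number from compound 1 to compound 4 (0.22 log units; within the scatter) in this assay, and a wide margin either way. Compound 4 is therefore expected to give about 20 nM, somewhere from 5 nM to 80 nM.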

Compound 4, half-maximal inhibitory concentration: 59 nM
Compound 4: the middle estimate sits 3.0-fold (0.47 log units) below what was measured, within the range that was stated.
By their numbers in this assay, from the lowest: compounds 1, 3, 2 and 4 (each within the scatter of the next, the first and the last beyond it).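

The aromatic carbon between two ring nitrogen atoms accepts azetidin-1-yl in place of hydrogen: in this assay this change gives a 4.9-fold higher number from compound 1 to compound 4 (0.69 log units; beyond the scatter) and so weakens inhibition without abolishing it. Going by these compounds alone, it is the only measured change on the shared core, whereas the earlier steps concerned only the aryl ring carrying the trifluoromethyl group, so this is the first sign that this position affects the read-out. No measurement on hand explains the weaker inhibition.

On these data alone, whether the shift belongs to azetidin-1-yl specifically or to any substituent on this carbon remains open, and an open-chain amine such as dimethylamino or a larger ring such as morpholin-4-yl would help to separate the two. Also open, as far as these compounds go, is whether a methoxy group, joined through oxygen rather than nitrogen, would behave in the same way.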